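Swapping a nitrobenzyl thioether for a bromobenzyl one

The compounds below may be only part of what the source reports. "The series", "measured", "known", "first", "only" and "open" are said of these compounds alone.

Three analogues sharing one core have been tested in a functional assay on HeLa cells (Homo sapiens) for antiproliferative activity, read by MTT assay, with a stated time of 24 h; on this read-out lower numbers stand for stronger inhibition and higher numbers for weaker inhibition. Compound 1 `O=[N+]([O-])c1ccccc1CSc1nnc(-c2ccc3c(c2)OCCO3)n1-c1ccccc1` gives 69800 nM, the highest of the three numbers. Compound 2 `Fc1ccccc1CSc1nnc(-c2ccc3c(c2)OCCO3)n1-c1ccccc1` gives 24300 nM in this assay, and compound 3 `Brc1cccc(CSc2nnc(-c3ccc4c(c3)OCCO4)n2-c2ccccc2)c1` gives 44200 nM. The step of a 2.9-fold lower number from compound 1 to compound 2 (0.46 log units; beyond the scatter) is the only one beyond the scatter; the step of a 1.6-fold lower number from compound 1 to compound 3 (0.20 log units; within the scatter) and the step of a 1.8-fold higher number from compound 2 to compound 3 (0.26 log units; within the scatter) both stay within it, so compound 2 and compound 3 cannot be ordered against each other, and compound 3 cannot be separated from compound 1.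

Compound 4 `Brc1ccc(CSc2nnc(-c3ccc4c(c3)OCCO4)n2-c2ccccc2)cc1` has not yet been measured in this assay. Its difference from compound 1 is 4-bromophenyl in place of 2-nitrophenyl on a saturated chain carbon bound to a sulfur. For the measured compounds named here, the closest precedent is the step of a 1.6-fold lower number from compound 1 to compound 3 (0.20 log units; within the scatter), in which a bromophenyl group also took the place of the 2-nitrophenyl group on the saturated chain carbon bound to a sulfur, and that step did not clear the scatter. On that basis compound 4 is expected to sit near compound 1 and compound 3, with a step of a 1.6-fold lower number from compound 1 to compound 4 (0.19 log units; within the scatter) that may not be distinguishable from scatter. Compound 4 is therefore estimated at 45000 nM in this assay, within a range from 15000 nM to 130000 nM.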

Compound 4, half-maximal inhibitory concentration: 54600 nM
Beside the measured number, compound 4's estimate is 1.2-fold (0.08 log units) below it; the measured number falls inside the stated range.
By their numbers in this assay, from the lowest: compounds 2, 3, 4 and 1 (each within the scatter of the next, the first and the last beyond it).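

With a 1.3-fold lower number from compound 1 to compound 4 (0.11 log units; within the scatter), a second bromophenyl group on the saturated chain carbon bound to a sulfur also fails to separate from the 2-nitrophenyl group in this assay, so the earlier result for compound 3 is no longer a single case. The step of a 1.2-fold higher number from compound 3 to compound 4 (0.09 log units; within the scatter) stays within the scatter as well, so the 3-bromophenyl and 4-bromophenyl groups cannot be told apart at this position, and these compounds give no sign that the site of the bromine matters here. The new step beyond the scatter, a 2.2-fold higher number from compound 2 to compound 4 (0.35 log units; beyond the scatter), is modest and sets the 2-fluorophenyl group apart from the 4-bromophenyl group, but compound 3 goes against any clean split between fluorine and bromine, since its own bromophenyl group remains within the scatter of the 2-fluorophenyl group.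

Nothing available bears on why these groups give such closely spaced numbers. As far as these compounds go, it also remains open whether an amine, a carboxylic acid or a longer chain at this position would give a number outside this narrow spread.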